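A Second Trifluoromethyl Group: What to Expect

The source may hold more compounds than are shown below. What is called first, only, known or untested is meant among the compounds shown, and "the series" means these compounds.

Measured compounds:
- compound 1 `CCN1CCN(c2ccc(NC(=O)c3cccc(C)c3)cc2Cl)CC1`: 3500 nM in a functional assay on CHO-K1 cells for antagonist activity at muscarinic acetylcholine receptor M5 (Homo sapiens), read by calcium flux; on this read-out lower numbers stand for stronger inhibition and higher numbers for weaker inhibition
- compound 2 `CCN1CCN(c2ccc(NC(=O)c3cccc(C(F)(F)F)c3)cc2Cl)CC1`: 4100 nM in this assay

Compound 2 stands alongside compound 1 in this assay; the step of a 1.2-fold higher number from compound 1 to compound 2 (0.07 log units; within the scatter) lies within the scatter, so the two numbers cannot be told apart. Compound 3 `CCN1CCN(c2ccc(NC(=O)c3cc(C(F)(F)F)cc(C(F)(F)F)c3)cc2Cl)CC1` differs from compound 2 by trifluoromethyl in place of hydrogen on an aromatic carbon. Among the compounds with values here, the only step that bears on this change is a 1.2-fold higher number from compound 1 to compound 2 (0.07 log units; within the scatter), which was small, so little movement beyond the scatter is expected in this assay. Compound 3 is therefore expected to give 5000 nM, within 2000 nM to 12000 nM, an estimated step of a 1.2-fold higher number from compound 2 to compound 3 (0.09 log units; within the scatter).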

Compound 3, half-maximal inhibitory concentration: > 10000 nM
Compound 3: a limit, no number (the forecaster's own chance of this, stated with the estimate: 15%); middle value at least 2.0-fold (0.30 log units) away from the limit.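

In this assay, trifluoromethyl in place of methyl moved nothing beyond the scatter, whereas adding a trifluoromethyl group meta to a trifluoromethyl group gives an at least 2.4-fold higher number from compound 2 to compound 3 (0.38 log units; beyond the scatter). This is the first change shown to weaken inhibition beyond the scatter, so this position is sensitive to what is placed on it. The reading for compound 3 is a limit, not a number, and the true size of the step stays unknown: the limit of > 10000 nM in this assay, at which 1 of the 3 values shown sits.

The compounds shown leave open whether an amine or a carboxylic acid at this position would fare any better. They also leave open whether the loss belongs to trifluoromethyl itself or would follow any group placed here.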